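Cyclopentyl amide in place of fluorocyclobutyl amide

The compounds below may be only part of what the source reports. "The series", "measured", "known", "first", "only" and "open" are said of these compounds alone.

Of the compounds shown here, three have numbers so far. Compound 1 `Cc1nc(S(C)(=O)=O)ccc1Oc1ncnc(OC2CCN(C(=O)SC3CC3)CC2)c1F` gives 126 nM in a functional assay on isolated protein for inhibition of Glucose-dependent insulinotropic receptor (Rattus norvegicus), read by HTRF and cAMP accumulation; a higher number here means that more compound is needed for the effect, a lower number that less compound is needed. Compound 2 `Cc1nc(S(C)(=O)=O)ccc1Oc1ncnc(OC2CCN(C(=S)OC(C)C)CC2)c1F` gives 1050 nM in this assay, and compound 3 `Cc1nc(S(C)(=O)=O)ccc1Oc1ncnc(OC2CCN(C(=O)C3(F)CCC3)CC2)c1F` gives 123 nM. Compound 3 holds the lowest of the three numbers, but its step to compound 1 lies within the scatter, so the two cannot be ordered; only compound 2 stands apart, as an 8.5-fold lower number from compound 2 to compound 3 (0.93 log units; beyond the scatter) shows.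

Compound 4 `Cc1nc(S(C)(=O)=O)ccc1Oc1ncnc(OC2CCN(C(=O)C3CCCC3)CC2)c1F` is not yet measured. It differs from compound 3 by a group of 5 heavy atoms (5 carbon; one five-membered non-aromatic ring of carbon only) in place of a group of 5 heavy atoms (4 carbon, 1 fluorine; one four-membered non-aromatic ring of carbon only), on a carbonyl carbon. Of the measured steps, the one that bears most directly on this change is a 1.0-fold lower number from compound 1 to compound 3 (0.01 log units; within the scatter), where a different carbon group on the same carbonyl carbon left the number unchanged. The two steps that involve compound 2, an 8.3-fold higher number from compound 1 to compound 2 (0.92 log units; beyond the scatter) and an 8.5-fold lower number from compound 2 to compound 3 (0.93 log units; beyond the scatter), alter the atoms attached to the ring nitrogen itself rather than the group on the carbonyl carbon, so they say little about this particular swap. On that basis no step beyond the scatter is expected in this assay for compound 4; the estimated step is a 1.1-fold higher number from compound 3 to compound 4 (0.06 log units; within the scatter). Compound 4 is therefore expected to give about 140 nM, in a range from 50 nM to 400 nM.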

Compound 4, half-maximal effective concentration: 407 nM
Compound 4: the middle estimate sits 2.9-fold (0.46 log units) below what was measured; the whole stated range lies below it.
By their numbers in this assay, from the lowest: compounds 3 and 1 (each within the scatter of the next); then compound 4; then compound 2.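

The group on the carbonyl carbon matters in this assay: cyclopentyl gives a 3.3-fold higher number from compound 3 to compound 4 (0.52 log units; beyond the scatter) and a 3.2-fold higher number from compound 1 to compound 4 (0.51 log units; beyond the scatter), so the match between compound 1 and compound 3 does not extend to every carbon group at this place. Compound 4 still stands apart from compound 2 (a 2.6-fold lower number from compound 2 to compound 4 (0.41 log units; beyond the scatter)), which puts the cyclopentyl amide on its own level, separate from both the pair of compound 1 and compound 3 and from compound 2. No measurement at hand offers an explanation for the step from the four-membered fluorinated ring to cyclopentyl.

In this swap, ring size and the presence of fluorine change together, so the compounds shown leave open which of the two accounts for the step; a plain cyclobutyl amide or a fluorocyclopentyl amide would separate them. Also open, as far as these compounds go, is how an open-chain group such as tert-butyl, or a ring carrying a hydroxyl group, would read on the same carbonyl carbon.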